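The source may hold more compounds than are shown below. What is called first, only, known or untested is meant among the compounds shown, and "the series" means these compounds.

In an ADME assay on RAW264.7 cells (Mus musculus) for cytotoxicity, read by MTT assay, with a stated time of 24 h, tested at 2.5 ug/mL (on this read-out higher numbers stand for a weaker effect at the one concentration tested and lower numbers for a stronger effect), the compounds of this study were compared on a single read-out. Compound 1, with the structure `COc1ccc(C(=O)CCc2ccc(OC)c(OC)c2)c(O)c1`, gives 89%, which is the highest of the two numbers recorded so far. Its nearest companion is compound 2, with the structure `COc1ccc(C(=O)/C=C/c2cccc(OC)c2OC)c(O)c1`, which gives 72.9%; that value lies below compound 1 by more than the usual scatter of repeated measurements, so the two compounds do differ on this read-out.

The next compound, compound 3, with the structure `COc1ccc(C(=O)CCc2ccc(OC)c(OC)c2OC)c(O)c1`, has not yet been measured. It differs from compound 1 in one place: methoxy in place of hydrogen on an aromatic carbon. Within the data shown here, no measured pair in this study isolates that particular change, so its size can only be anticipated. A change of this kind is expected to move this assay little, at most a modest decrease, and may well stay within the scatter.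

Compound 3 is therefore expected to give 84%, within a range from 68% to 98%, an estimated step of a number 5 percentage points lower from compound 1 to compound 3 (within the scatter).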

Compound 3, a percentage reported as activity, at one concentration (the size of the read-out at that concentration, not a potency): 94.4%
Beside the measured number, compound 3's estimate is 10.4 percentage points below it; measured number inside the range.
By their numbers in this assay, from the lowest: compound 2; then compounds 1 and 3 (each within the scatter of the next).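

In this assay, placing a methoxy group on this aromatic carbon, ortho to a large group and ortho to a methoxy group, gives a number 5.4 percentage points higher from compound 1 to compound 3 (within the scatter). Among these compounds, this is the first change in a single place that can be read, and it shows that this position takes the added methoxy, with its 2 heavy atoms, without any difference that can be separated from the usual scatter, so compound 1 and compound 3 cannot be told apart on this read-out. No measurement available here explains why this swap leaves the read-out so close.

The compounds shown carry only hydrogen or methoxy at this carbon, so it remains open whether an amine, a carboxylic acid or a longer chain such as butoxy would also read within the scatter of compound 1. Going by these compounds, it also remains open whether the same swap would give a similar result on another compound, or at other concentrations, since this single step comes from one pair tested at one concentration.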